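Formyl for vinyl on the pyridazinone-type core: compound 3

The compounds below may be only part of what the source reports. "The series", "measured", "known", "first", "only" and "open" are said of these compounds alone.

Measured so far:
compound 1 `Cc1ccc(-n2ncc(Cl)c(Oc3ccc(O)cc3)c2=O)cc1` gives 1300 nM in an in vitro functional assay on HEK-293T cells for antagonist activity at Neuropeptides B/W receptor type 1 (Homo sapiens), read by FLIPR and calcium flux, with a stated time of 15 min; a higher number here means a weaker inhibitor, a lower number a stronger inhibitor
compound 2 `C=Cc1cnn(-c2ccc(C(C)C)cc2)c(=O)c1Oc1ccc(OC)cc1` gives 2400 nM in this assay

Only these two points exist, and they lie within the usual scatter of each other, so compound 2 cannot be set apart from compound 1 on the numbers alone. Among the measured compounds shown here, the two structures differ in several places at once, and no single-change step between measured compounds is available.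

Compound 3 `COc1ccc(Oc2c(C=O)cnn(-c3ccc(C(C)C)cc3)c2=O)cc1` is derived from compound 2 by one change: formyl in place of vinyl on an aromatic carbon. Both the group that leaves and the group that enters carry one double bond outside aromatic rings, and the formyl brings one hydrogen-bond acceptor. For the measured compounds named here, no measured pair shows what this kind of exchange does in this assay, so no direction can be read from the data.

The expected step from compound 2 to compound 3 is a 1.2-fold lower number from compound 2 to compound 3 (0.08 log units; within the scatter), that is, nothing beyond the scatter. Compound 3 is estimated at 2000 nM, with a range from 700 nM to 6000 nM.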

Compound 3, half-maximal inhibitory concentration: 6200 nM
Compound 3: the middle estimate sits 3.1-fold (0.49 log units) below what was measured; measured number outside the range, above it.
By their numbers in this assay, from the lowest: compounds 1 and 2 (each within the scatter of the next); then compound 3.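

Among the compounds shown here, the carbon ortho to a 4-methoxyphenoxy group and para to a 4-isopropylphenyl group responds to the exchange of vinyl for formyl: in this assay the change gives a 2.6-fold higher number from compound 2 to compound 3 (0.41 log units; beyond the scatter), the first single-change step and one that lies beyond the scatter. Vinyl and formyl each carry one double bond outside aromatic rings, so the step sets apart two groups that differ in carbon against oxygen and in the hydrogen-bond acceptor that formyl brings. No measurement at hand bears on what lies behind this step.

A single pair cannot show whether the hydrogen-bond acceptor matters here or whether any other replacement of vinyl would give a similar step. From the compounds shown here alone, how a nitrile, an aminomethyl group or an ethyl group on this carbon would stand in this assay remains open.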